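This account rests on a few compounds, and the source may have more. Where it says the series, first, only, none or still open, it means among the compounds named here.

Measured compounds in a functional assay on L1210 cells (Mus musculus) for inhibition; a lower number here means a stronger inhibitor, a higher number a weaker inhibitor:

compound 1 `NC(=O)c1ncn(C2O[C@H](CO)[C@@H](O)[C@H]2O)c1C#CCO` — 0.7 ug/mL
compound 2 `CC(C)(O)C#Cc1c(C(N)=O)ncn1C1O[C@H](CO)[C@@H](O)[C@H]1O` — 4.8 ug/mL
compound 3 `N#Cc1ncn(C2O[C@H](CO)[C@@H](O)[C@H]2O)c1C#CCO` — 4.1 ug/mL

Compound 3 sits second highest of the three numbers in this assay. Its nearest neighbour is compound 2, and the two lie within the scatter of each other, so no order between them can be read. Compound 1 lies well away, as the step of a 5.9-fold higher number from compound 1 to compound 3 (0.77 log units; beyond the scatter) shows.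

Compound 4 `CCCC#Cc1c(C#N)ncn1C1O[C@H](CO)[C@@H](O)[C@H]1O` differs from compound 3 in one place: ethyl in place of hydroxy on a saturated chain carbon bound to a triple-bonded carbon. Within the data shown here, no measured step removes the hydroxy at that position. The step that comes closest is the one at the same end of the chain, a 6.9-fold higher number from compound 1 to compound 2 (0.84 log units; beyond the scatter), in which hydroxymethyl grew to 1-hydroxy-1-methylethyl while the hydroxy was kept. The step of a 5.9-fold higher number from compound 1 to compound 3 (0.77 log units; beyond the scatter) sits on the aromatic carbon and does not bear on the alkyne end.

Taking the one relevant step as a loose guide, a modest rise in the number for compound 4 is expected, with wide uncertainty since the loss of the hydroxy itself is untested here. The expected step is a 2.4-fold higher number from compound 3 to compound 4 (0.39 log units; beyond the scatter). Compound 4 is therefore estimated at 10 ug/mL, within 3 ug/mL to 35 ug/mL.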

Compound 4, half-maximal inhibitory concentration: 14.8 ug/mL
The estimate for compound 4 lay 1.5-fold (0.17 log units) below the measured number; the range from low to high includes it.
By their numbers in this assay, from the lowest: compound 1; then compounds 3 and 2 (each within the scatter of the next); then compound 4.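

In this assay, among these compounds, the step of a 3.6-fold higher number from compound 3 to compound 4 (0.56 log units; beyond the scatter) is the first direct reading of a change that removes the hydroxy from the saturated chain carbon bound to a triple-bonded carbon, whereas the earlier step at this end of the chain, a 6.9-fold higher number from compound 1 to compound 2 (0.84 log units; beyond the scatter), kept the hydroxy in place. Both changes at this end raise the number, and no step shown here lowers it, although this pattern rests on just these two pairs, which have different groups on the aromatic carbon. No measurement in hand bears on what lies behind the rise.

Among the compounds shown here, because ethyl enters as hydroxy leaves, this single step does not separate the loss of the hydroxy from the extension of the chain, and pent-1-yn-1-yl is seen only with the nitrile on the aromatic carbon, so its behaviour with carbamoyl there remains open. An amine or a carboxylic acid at the end of the chain, or a chain longer than pent-1-yn-1-yl, would show how far this position tolerates other groups.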